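The source may hold more compounds than are shown below. What is called first, only, known or untested is meant among the compounds shown, and "the series" means these compounds.

Measured compounds
Compound 1 `CCOC(=O)c1cn(C)c2cc(Cl)ccc2c1=O` — > 50000 nM (a limit of the assay, not a number)
Compound 2 `CCOC(=O)c1cn(Cc2ccccc2)c2cc(Cl)ccc2c1=O` — 16200 nM

In a functional assay on HeLa cells (Homo sapiens) for cytotoxicity, read by MTT assay, with a stated time of 24 h (a higher number here means a weaker inhibitor, a lower number a stronger inhibitor), compound 1 gives > 50000 nM, which is a limit of the assay and not a number. For the measured compounds named here, compound 2 gives 16200 nM in this assay; it is the only number in the set. Going by the values given here, the single measured step is an at least 3.0-fold lower number from compound 1 to compound 2 (0.48 log units; beyond the scatter). Compound 3 `CCOC(=O)c1cn(CC)c2cc(Cl)ccc2c1=O` differs from compound 2 by methyl in place of phenyl on a saturated chain carbon bound to an aromatic nitrogen, which undoes most of the measured step and leaves ethyl where benzyl stood. Among the compounds with values here, the measured step is the only guide, and a higher number of about that size is expected from compound 2 to compound 3, with a real chance that the result is only (the limit of > 50000 nM in this assay, at which 1 of the 2 values shown sits). Compound 3 is estimated at 40000 nM, with a range of 15000 nM to 100000 nM. The expected step is a 2.5-fold higher number from compound 2 to compound 3 (0.39 log units; beyond the scatter).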

Compound 3, half-maximal inhibitory concentration: > 50000 nM
Compound 3 gave a limit, no number; the forecaster's own chance of this, stated with the estimate: 45%; at least 1.2-fold (0.09 log units) between middle value and limit.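

In this assay the change from benzyl to ethyl gives an at least 3.0-fold higher number from compound 2 to compound 3 (0.48 log units; beyond the scatter), so the lower number of compound 2 does not survive with methyl in place of phenyl on this saturated chain carbon. Among the compounds shown, a measurable value at this position therefore goes with the phenyl and not with chain extension alone, although the step from compound 1 to compound 3 cannot be read, since both values are limits of the assay and not numbers. Compound 2 remains the only compound with a number, and the limit now holds most of the set: the limit of > 50000 nM in this assay, at which 2 of the 3 values shown sit.

Going by these compounds, whether the phenyl must be aromatic stays open; cyclohexyl in its place or a longer chain such as butyl would test this. Also open, on these data alone, is how an amine or a carboxylic acid on the phenyl would shift the number of compound 2.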